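A few compounds are considered here, and "the series" means these few. Any claim that something is new, unique, unknown or untested is made for them only; others in the source may bear on it.

Of the compounds shown here, two have been measured here. For the measured compounds named here, compound 1 `CO[C@@H]1CC=C2NN(c3ccc(C)cc3)C(=O)CC[C@]2(c2ccccc2)O1` and compound 2 `CO[C@@H]1CC=C2N(c3ccc(C)cc3)C(=O)C[C@]2(c2ccccc2)O1` carry the same 4-methylphenyl group and the same phenyl group, but on cores that differ in more than one place, so no single step connects them. In a functional assay on DU-145 cells (Homo sapiens) for cytotoxicity, read by sulforhodamine B assay, with a stated time of 48 h (a lower number here means a stronger inhibitor, a higher number a weaker inhibitor), compound 1 gives 2200 nM, and in this assay compound 2 gives 4400 nM. Compound 2 thus shows the higher of the two numbers, yet the gap to compound 1 lies within the usual scatter of repeated measurements, so the two cannot be told apart. Compound 3 `CO[C@@H]1CC=C2N(c3cc(Cl)cc(Cl)c3)C(=O)C[C@]2(c2ccccc2)O1` is built from compound 2 by one change: 3,5-dichlorophenyl in place of 4-methylphenyl on an amide-type nitrogen in a ring. Going by the values given here, no measured pair shows what such a change does on this core, so there is no basis for expecting a large shift in either direction. The expected step is a 1.3-fold lower number from compound 2 to compound 3 (0.10 log units; within the scatter), within the scatter. Compound 3 is therefore estimated at 3500 nM, with a range from 1200 nM to 10000 nM.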

Compound 3, half-maximal inhibitory concentration: 8170 nM
Beside the measured number, compound 3's estimate is 2.3-fold (0.37 log units) below it; the range from low to high includes it.
By their numbers in this assay, from the lowest: compounds 1, 2 and 3 (each within the scatter of the next, the first and the last beyond it).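

Placing 3,5-dichlorophenyl instead of 4-methylphenyl on the amide-type nitrogen gives a 1.9-fold higher number from compound 2 to compound 3 (0.27 log units; within the scatter) in this assay, and this is the first pair shown that differs in one place only. On this core, then, the position takes a phenyl ring with two chlorine atoms in place of one with a methyl group, with no difference that can be told from the spread of repeated measurements. Nothing available here explains this result, which rests on a single pair.

Going by these compounds, it remains open whether a different kind of group at this nitrogen, such as a phenyl ring bearing an amine or a carboxylic acid, or a longer chain in place of the ring, would move the number beyond the scatter. On these data alone, whether the same swap would behave alike on the core of compound 1 is also open.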